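A few compounds are considered here, and "the series" means these few. Any claim that something is new, unique, unknown or untested is made for them only; others in the source may bear on it.

Of the compounds shown here, two have numbers so far. In a functional assay on MDA-MB-435 cells (Homo sapiens) for antiproliferative activity, read by sulforhodamine B assay, with a stated time of 48 h (a higher number here means a weaker inhibitor, a lower number a stronger inhibitor), compound 1 (`COc1ccc(-c2nsc3c2NC(=O)CC3c2cccc(OC)c2)cc1`) gives 282 nM and compound 2 (`COc1ccc(-c2nsc3c2NC(=O)CC3c2ccc3c(c2)OCCO3)cc1`) gives 247 nM as its value, so the two stand within the usual scatter of each other and neither can be ranked above the other. Among the measured compounds shown here, compound 1 therefore sits level with the only other number available.

The next compound, compound 3 (`COc1ccc(-c2nsc3c2NC(=O)CC3c2cccc(Cl)c2)cc1`), keeps the core of compound 1 and alters one substituent (chloro in place of methoxy on an aromatic carbon) with chloro in place of methoxy on an aromatic carbon. The change lies on a six-membered aromatic ring of carbon only, meta to a large group, and turns 3-methoxyphenyl into 3-chlorophenyl.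

For the measured compounds named here, no measured pair shows what a change of this kind does, so the data give no direct guide to its direction. The expectation is therefore of no shift beyond the scatter, and the estimated change a 1.1-fold higher number from compound 1 to compound 3 (0.03 log units; within the scatter) is small. For compound 3 the expected value in this assay is 300 nM with an estimated range from 110 nM to 800 nM around it.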

Compound 3, half-maximal inhibitory concentration: 749 nM
The estimate for compound 3 lay 2.5-fold (0.40 log units) below the measured number; the measured number falls inside the stated range.
By their numbers in this assay, from the lowest: compounds 2 and 1 (each within the scatter of the next); then compound 3.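

In this assay, among the compounds shown here, the change from 3-methoxyphenyl to 3-chlorophenyl gives a 2.7-fold higher number from compound 1 to compound 3 (0.42 log units; beyond the scatter) as a modest loss, the first step in this set that stands beyond the scatter. For the compounds shown here, the earlier pair stood level and offered no step, whereas this result shows that the substituent at this place, on an aromatic carbon meta to a large group, can alter the number. The methoxy that leaves has one more heavy atom and one more hydrogen-bond acceptor than the chloro that enters, but no measurement here separates these differences or accounts for the step.

Going by these compounds, it remains open whether the methoxy of compound 1 is matched or surpassed by other groups at this place, such as a hydroxyl, an amine or a longer ethoxy chain. This single step also leaves open whether chloro in place of methoxy would have a similar effect elsewhere on the molecule, including on the methoxyphenyl that all three compounds share, so it sets no general pattern for this change.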